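The source may report more compounds than this note shows. Statements on the series, on what has been measured and on what is new or still open speak of the compounds shown alone.

Compound 1 `CCCCCCCCc1ccc(OCC(=O)Cn2cnnn2)cc1`: 22%
Compound 2 `CCCCCCCCc1ccc(OCC(=O)Cn2nnc(Cc3ccccc3)n2)cc1`: < 5%

Both compounds were tested in an ADME assay on S9 fraction from liver (Rattus norvegicus) for metabolic stability, read by LC-MS, using NADPH, with a stated time of 30 min; a higher number here means that more of the compound is left, a lower number that less of the compound is left. Compound 2 gives < 5%, which is a limit of the assay and not a number. Compound 1, by contrast, gives a measured number, 22%. Only these two results are available, so compound 2 can be placed no more exactly than at that limit.

The next compound, compound 3 `CCCCCCCCc1ccc(OCC(=O)Cn2nnc(C(=O)O)n2)cc1`, keeps the rest of compound 2 and carries carboxy in place of benzyl on an aromatic carbon. Going by the values given here, no pair of measured compounds differs in one place only, so the data offer no direct measure of such a change. The expectation leans on compound 1, which carries no benzyl and gives 22%. In this assay a rise beyond the usual scatter is therefore expected, with an estimated step of a number at least 25 percentage points higher from compound 2 to compound 3 (beyond the scatter), although its size remains uncertain. Compound 3 is estimated at 30%, with an expected range from 8% to 65%.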

Compound 3, percent of the compound remaining: 52%
Estimate against measurement, compound 3: 22 percentage points below; the measured number falls inside the stated range.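

In this assay, going by these compounds alone, carboxy in place of benzyl on an aromatic carbon, between two ring nitrogen atoms, gives a number at least 47 percentage points higher from compound 2 to compound 3 (beyond the scatter), the first step that can be read at this position. Going by these compounds, compound 2 stands at a limit of the assay and not at a number, so this step has only a lower bound and its full size stays unknown: the limit of < 5% in this assay, at which 1 of the 3 values shown sits. Compound 3 can also be set against compound 1, where 5-carboxy-2H-tetrazol-2-yl in place of 1H-tetrazol-1-yl gives a number 30 percentage points higher from compound 1 to compound 3 (beyond the scatter), but that change alters how the ring is attached as well as adding carboxy, so it cannot be credited to carboxy alone.

The compounds shown leave open whether the rise from compound 2 belongs to carboxy itself or simply to the loss of benzyl, a question that a hydrogen, a methyl ester or a primary amide on the same aromatic carbon would help to settle. They also leave open how far the result depends on the octyl chain, which all three compounds share, and whether a shorter chain or an ether in that chain would change the amount of compound left.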